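The source may report more compounds than this note shows. Statements on the series, on what has been measured and on what is new or still open speak of the compounds shown alone.

In a functional assay on MCF7 cells (Homo sapiens) for antiproliferative activity, read by MTT assay (on this read-out higher numbers stand for weaker inhibition and lower numbers for stronger inhibition), compound 1 `Cc1c(-n2cc(COc3ccc(/C=C/C(=O)c4cc5c(cc4O)OC(C)(C)CC5)cc3)nn2)cccc1[N+](=O)[O-]` gives 176000 nM while compound 2 `CC(=O)c1ccc(-n2cc(COc3ccc(/C=C/C(=O)c4cc5c(cc4O)OC(C)(C)CC5)cc3)nn2)cc1` gives 182000 nM on the same read-out. Their step of a 1.0-fold higher number from compound 1 to compound 2 (0.01 log units; within the scatter) stays within the scatter, with 4-acetylphenyl in place of 2-methyl-3-nitrophenyl on an aromatic nitrogen. Compound 3 `CCc1ccccc1-n1cc(COc2ccc(/C=C/C(=O)c3cc4c(cc3O)OC(C)(C)CC4)cc2)nn1` has no number and is reported as "not active" (no number reported) in the study. The difference 3-bromo-4-methylphenyl in place of 2-ethylphenyl on an aromatic nitrogen gives compound 4 `Cc1ccc(-n2cc(COc3ccc(/C=C/C(=O)c4cc5c(cc4O)OC(C)(C)CC5)cc3)nn2)cc1Br` with 3-bromo-4-methylphenyl in place of 2-ethylphenyl on an aromatic nitrogen. Among the compounds with values here, only the step between compound 1 and compound 2 bears on this change. With no number for compound 3, no size or direction of step can be set from it. A value near the two measured ones is expected, though another report without a number remains possible. Compound 4 is estimated at 180000 nM within an expected range of 80000 nM to 400000 nM on this read-out.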

Compound 4, half-maximal inhibitory concentration: "not active" (no number reported)
Compound 4: no number reported; there is nothing to compare the estimate with.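

Compound 3 and compound 4 are both reported as not active without a number, so no step can be read between them. The compounds shown leave open how far 3-bromo-4-methylphenyl and 2-ethylphenyl differ on this assay. No supporting evidence bears on this result.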